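A Longer Linker and a Tolyl Sulfonamide on the Shared Core

The compounds below may be only part of what the source reports. "The series", "measured", "known", "first", "only" and "open" are said of these compounds alone.

Compound 2 `O=S(=O)(NCCNc1nccc(-c2c(-c3cccc(F)c3)nc3sccn23)n1)c1ccc(F)cc1` carries the shared core with a sulfonamide on its two-carbon chain. In a functional assay on A-375 cells (Homo sapiens) for cytotoxicity, read by MTT assay (a lower number here means a stronger inhibitor, a higher number a weaker inhibitor), compound 2 gives 9450 nM, the highest of the three numbers measured. Compound 1 `O=C(NCCNc1nccc(-c2c(-c3cccc(F)c3)nc3sccn23)n1)c1c(F)cccc1F` gives 2700 nM, and compound 3 `O=S(=O)(NCCNc1nccc(-c2c(-c3cccc(F)c3)nc3sccn23)n1)c1ccc(C(F)(F)F)cc1` gives 7440 nM. The step of a 3.5-fold higher number from compound 1 to compound 2 (0.54 log units; beyond the scatter) lies beyond the scatter, whereas a 1.3-fold lower number from compound 2 to compound 3 (0.10 log units; within the scatter) lies within it.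

Compound 4 `Cc1ccc(S(=O)(=O)NCCCNc2nccc(-c3c(-c4cccc(F)c4)nc4sccn34)n2)cc1` differs from compound 2 by (((4-methylphenyl)sulfonyl)amino)methyl in place of ((4-fluorophenyl)sulfonyl)amino on a saturated chain carbon, two bonds along the chain from a nitrogen on an aromatic ring. Two things change together: the chain gains one carbon, and the substituent on the sulfonyl-bearing ring turns from fluoro to methyl. Of the measured steps only a 1.3-fold lower number from compound 2 to compound 3 (0.10 log units; within the scatter) bears on this, since it too swapped the substituent on that ring, and it stayed within the scatter. Within the data shown here, no measured pair speaks to the longer chain. The sulfonamide itself is retained, so the larger step of a 3.5-fold higher number from compound 1 to compound 2 (0.54 log units; beyond the scatter), which exchanged the carbonyl for the sulfonyl, is not expected to recur.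

Compound 4 is therefore expected to give no step beyond the scatter, a 1.2-fold lower number from compound 2 to compound 4 (0.07 log units; within the scatter). For compound 4 the estimate in this assay is 8000 nM, with a range from 3000 nM to 25000 nM.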

Compound 4, half-maximal inhibitory concentration: 8380 nM
For compound 4 the middle estimate is 1.0-fold (0.02 log units) below the measured one, within the range that was stated.
By their numbers in this assay, from the lowest: compound 1; then compounds 3, 4 and 2 (each within the scatter of the next).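

In this assay, replacing ((4-fluorophenyl)sulfonyl)amino with (((4-methylphenyl)sulfonyl)amino)methyl on a saturated chain carbon gives a step that stays within the scatter (a 1.1-fold lower number from compound 2 to compound 4 (0.05 log units; within the scatter)), so the longer chain and the methyl, taken together, produce no change that can be read. Among these compounds, the result also gives the first reading of a sulfonamide against the carbonyl compound with this chain change included, and the step is beyond the scatter (a 3.1-fold higher number from compound 1 to compound 4 (0.49 log units; beyond the scatter)), in the same direction as the one printed between the carbonyl and sulfonyl groups on the shorter chain. No measurement is available that would explain these numbers.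

The compounds shown do not separate the longer chain from the methyl, since both change at once in compound 4, and a contribution from one could be offset by the other. As far as these compounds go, how a carbonyl group would read on the longer chain stays open, as do a still longer chain and an amine or a carboxylic acid in place of the methyl.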